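A few compounds are considered here, and "the series" means these few. Any claim that something is new, unique, unknown or untested is made for them only; others in the source may bear on it.

Compound 1 `C=CCn1c(=O)/c(=C\c2cccc(C)c2)[nH]c(=O)/c1=C\c1ccccc1OC` carries a 3-methylphenyl on the shared core; in a functional assay on MCF7 cells (Homo sapiens) for cytotoxicity, read by CCK-8 assay, with a stated time of 72 h (on this read-out higher numbers stand for weaker inhibition and lower numbers for stronger inhibition), compound 1 gives 20700 nM. Among the measured compounds it stands second highest: compound 3 `C=CCn1c(=O)/c(=C\c2ccccc2F)[nH]c(=O)/c1=C\c1ccccc1OC`, which gives 23000 nM, lies within the scatter of it, while compound 2 `C=CCn1c(=O)/c(=C\c2cccc(Br)c2)[nH]c(=O)/c1=C\c1ccccc1OC`, which gives 5400 nM, sits furthest away. Among the measured compounds shown here, the step of a 3.8-fold lower number from compound 1 to compound 2 (0.58 log units; beyond the scatter) is the one change that bears directly on the question here, since it exchanges the methyl for a halogen at the same place. The other steps, a 1.1-fold higher number from compound 1 to compound 3 (0.05 log units; within the scatter) and a 4.3-fold higher number from compound 2 to compound 3 (0.63 log units; beyond the scatter), move the substituent elsewhere on the phenyl and tell nothing about such an exchange.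

Compound 4 `C=CCn1c(=O)/c(=C\c2ccc(Cl)c(Cl)c2)[nH]c(=O)/c1=C\c1ccccc1OC` has not yet been measured. It differs from compound 1 in 3,4-dichlorophenyl in place of 3-methylphenyl on a double-bonded chain carbon bound to an aromatic carbon. Chlorine in place of methyl matches the kind of exchange seen in a 3.8-fold lower number from compound 1 to compound 2 (0.58 log units; beyond the scatter), so a lower number than compound 1 is expected, of roughly that size; the second chlorine has no precedent in the series and widens the range. The expected step is a 3.5-fold lower number from compound 1 to compound 4 (0.54 log units; beyond the scatter). For compound 4 the estimate in this assay is 6000 nM, within 2500 nM to 15000 nM.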

Compound 4, half-maximal inhibitory concentration: "not active" (no number reported)
Compound 4: no number reported, so the estimate cannot be set against anything.
By their numbers in this assay, from the lowest: compound 2; then compounds 1 and 3 (each within the scatter of the next).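

Among the compounds shown here, compound 4 is recorded as "not active" in this assay with no number reported, so no step between it and compound 1, or any other compound, can be read. No measured evidence bears on this result. The compounds shown leave open how far compound 4, with its 3,4-dichlorophenyl, lies from compounds 1, 2 and 3 on this read-out.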